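From allyloxy to ethoxy on the shared core

A few compounds are considered here, and "the series" means these few. Any claim that something is new, unique, unknown or untested is made for them only; others in the source may bear on it.

Compound 1 `C=CCOc1ccc2c(NCCCN(C)C)ccnc2c1` was assessed in a functional assay on DLD-1 cells (Homo sapiens) for cytotoxicity, read by MTT assay, with a stated time of 48 h (a higher number here means a weaker inhibitor, a lower number a stronger inhibitor), where compound 1 gives 5180 nM. Of the two numbers measured, this is the highest; the nearest is compound 2 `CC(C)COc1ccc2c(Cl)ccnc2c1`, which in this assay gives 3100 nM, a gap that lies within the usual scatter of the measurement, so the two compounds cannot be told apart on these data. Compound 3 `CCOc1ccc2c(NCCCN(C)C)ccnc2c1` has not yet been measured. It differs from compound 1 in one place: methyl in place of vinyl on a saturated chain carbon bound to an oxygen on an aromatic ring. Going by the values given here, no measured pair shows this change, so there is no direct step to lean on. Among the compounds with values here, the change is small, a shortening of the allyloxy group to ethoxy, and no step in this assay beyond the scatter is expected in either direction. The estimate for compound 3 in this assay is therefore 5000 nM, within a range from 2000 nM to 12000 nM. The expected step is a 1.0-fold lower number from compound 1 to compound 3 (0.02 log units; within the scatter).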

Compound 3, half-maximal inhibitory concentration: 8540 nM
The estimate for compound 3 lay 1.7-fold (0.23 log units) below the measured number; the measured number falls inside the stated range.
By their numbers in this assay, from the lowest: compounds 2, 1 and 3 (each within the scatter of the next, the first and the last beyond it).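

Going by these compounds alone, compound 1 and compound 3 form the first measured pair that differs in one place, and so give a direct reading in this assay of the exchange of allyloxy for ethoxy on the shared core (a 1.6-fold higher number from compound 1 to compound 3 (0.22 log units; within the scatter)). At this place, on a saturated chain carbon bound to an oxygen on an aromatic ring, the loss of one carbon and of the double bond outside aromatic rings leaves the two compounds indistinguishable on these data. No supporting measurement bears on this result.

Compound 2 differs from compound 1 in more than one place, so it adds no reading of this change. From the compounds shown here alone, whether a longer chain such as hexyloxy, or an amine or a carboxylic acid carried on the chain, would give a step beyond the scatter remains open.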